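Swapping the aryl group on a quinoline-type core for permeability

This account rests on a few compounds, and the source may have more. Where it says the series, first, only, none or still open, it means among the compounds named here.

Compound 1, `COc1cccc(CNCCCNc2ccnc3cc(-c4ccc(C(F)(F)F)cc4)ccc23)c1O`: 237 10^-6 cm/s
Compound 2, `COc1ccc(F)cc1CNCCCNc1ccnc2cc(Cc3ccc(F)cc3Cl)ccc12`: 23 10^-6 cm/s

Of the compounds shown here, two have been measured in an ADME assay for permeability, using PAMPA, with a stated time of 30 min, at pH 7.4; on this read-out lower numbers stand for lower permeability and higher numbers for higher permeability. Compound 1 gives the highest of the two numbers; its nearest neighbour, compound 2, gives a lower number, a gap that lies beyond the usual scatter of this assay. Among the measured compounds shown here, no step between the two measured compounds rests on a single change of structure, so their values are taken only as they stand.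

The unmeasured compound 3, `COc1cccc(CNCCCNc2ccnc3cc(Cc4ccc(F)cc4)ccc23)c1O`, differs from compound 1 in one place: 4-fluorobenzyl in place of 4-(trifluoromethyl)phenyl on an aromatic carbon. For the measured compounds named here, the step from compound 1 to compound 3 is expected to be a moderate fall, a 2.0-fold lower number from compound 1 to compound 3 (0.30 log units; within the scatter), with the only other measured compound, compound 2, sitting at 23 10^-6 cm/s as a loose lower reference. Compound 3 is therefore estimated at 120 10^-6 cm/s, with a range from 40 10^-6 cm/s to 300 10^-6 cm/s, pending the measurement.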

Compound 3, apparent permeability: 23 10^-6 cm/s
Compound 3: middle estimate off by 5.2-fold (0.72 log units), on the high side; measured number outside the range, below it.
By their numbers in this assay, from the lowest: compounds 2 and 3 (each within the scatter of the next); then compound 1.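

In this assay, placing 4-fluorobenzyl instead of 4-(trifluoromethyl)phenyl on this aromatic carbon of the shared core brings a 10-fold lower number from compound 1 to compound 3 (1.01 log units; beyond the scatter) and so forms a large step, well beyond the scatter. This is the only single-place step among the compounds shown, and it establishes that the read-out can respond strongly to the group at this position while the rest of the structure stays fixed. No measurement shown accounts for the size of this step.

The change alters both the link to the ring and the group on that ring, so the compounds shown cannot separate the two. On these data alone, it remains open where 4-(trifluoromethyl)benzyl or 4-fluorophenyl would fall at this position, and what an amine or a carboxylic acid on that ring would do.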